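A few compounds are considered here, and "the series" means these few. Any claim that something is new, unique, unknown or untested is made for them only; others in the source may bear on it.

Compound 1 `Cc1nc(N)nc2c1c(-c1ccc3oc(N)nc3c1)nn2C(C)C` gives > 95% in an ADME assay on microsomes from liver (Homo sapiens) for metabolic stability, read by LC-MS, with a stated time of 15 min, tested at 1 uM, in the presence of a further agent that is not named here; a higher number here means that more of the compound is left, a lower number that less of the compound is left; this value is a limit of the assay.
Compound 2 `CC(C)n1nc(-c2ccc3oc(N)nc3c2)c2c(CO)nc(N)nc21` gives > 95% in this assay; this value is a limit.
Compound 3 `COc1nc(N)nc2c1c(-c1ccc3oc(N)nc3c1)nn2C(C)C` gives > 95% in this assay; this value too is a limit.

Compound 2 therefore stands at the limit of this assay, where all three measured compounds sit (the limit of > 95% in this assay, at which 3 of the 3 values shown sit), and no number separates it from compound 1 or compound 3. Compound 4 `CC(C)n1nc(-c2ccc3oc(N)nc3c2)c2c(Cl)nc(N)nc21` is the next compound to be measured in this assay. It differs from compound 2 in one place: chloro in place of hydroxymethyl on an aromatic carbon. Within the data shown here, two measured steps touch the same position of the shared core. The step that the two limits leave unreadable from compound 1 to compound 2 and the step that the two limits leave unreadable from compound 2 to compound 3 both lie between limits, so their sizes cannot be read and they give no direction. On this basis no step beyond the scatter is expected for compound 4, though a limit on each side leaves the size open. Compound 4 is expected to remain near the limit in this assay, estimated at 92% with a range from 75% to 99%. The expected step of a number at least 3 percentage points lower from compound 2 to compound 4 (that floor lies within the scatter) is accordingly small.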

Compound 4, percent of the compound remaining: 92%
Compound 4: the middle estimate sits on the measured number at the digits printed; low and high end bracket the measured number.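

Among these compounds, with chloro at this position, next to the ring nitrogen, compound 4 gives 92% in this assay, the first reading at this position that is a number and not a limit. From the compounds shown here alone, the result can be read as a number at least 3 percentage points lower from compound 2 to compound 4 (that floor lies within the scatter), as a number at least 3 percentage points lower from compound 3 to compound 4 (that floor lies within the scatter) and as a number at least 3 percentage points lower from compound 1 to compound 4 (that floor lies within the scatter), so the change to chloro shows no step beyond the scatter from any of the three groups it can be set against, although the upper ends of these steps stay open. The other compounds remain at the limit: the limit of > 95% in this assay, at which 3 of the 4 values shown sit.

Going by these compounds, the true size of each of these steps stays open, as do the steps among the three compounds at the limit, which cannot be read. Also open, on these data alone, is whether an amine, a carboxylic acid or a longer chain at this position would give a step beyond the scatter.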